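Mirror-image step from compound 2 to compound 3

The compounds below may be only part of what the source reports. "The series", "measured", "known", "first", "only" and "open" are said of these compounds alone.

Compound 1 `CCCCC[C@H](CCC[C@@H]1CC=CC(=O)O1)OC`: 20500 nM
Compound 2 `CCCCC[C@@H](CCC[C@@H]1CC=CC(=O)O1)OC`: 11500 nM

Within the data shown here, in a functional assay on A2780 ADR cells (Homo sapiens) for cytotoxicity, read by MTT assay, with a stated time of 24 h (on this read-out higher numbers stand for weaker inhibition and lower numbers for stronger inhibition), compound 2 gives 11500 nM, which stands within the scatter of its only neighbour, compound 1 at 20500 nM. Next is compound 3 `CCCCC[C@H](CCC[C@H]1CC=CC(=O)O1)OC`, not yet measured: the two compounds have the same atoms and bonds and differ only in configuration as drawn: 2 of 2 stereo elements differ (all stereocentres are inverted: mirror images); a stereocentre at a saturated chain carbon is drawn S in compound 2 and R in compound 3; a stereocentre at a saturated ring carbon is drawn R in compound 2 and S in compound 3. Among the measured compounds shown here, only one measured step bears on this change: a 1.8-fold lower number from compound 1 to compound 2 (0.25 log units; within the scatter). Going by these compounds, that step inverts the saturated chain carbon alone, so the effect of inverting the saturated ring carbon remains untested in this pair of data. For the measured compounds named here, with only that step as a guide, no shift beyond the scatter is expected in this assay, though the range is kept wide for the untested centre. The expected step is a 1.2-fold higher number from compound 2 to compound 3 (0.09 log units; within the scatter). The estimate for compound 3 is 14000 nM. The expected range for compound 3 runs from 5500 nM to 36000 nM.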

Compound 3, half-maximal inhibitory concentration: 12200 nM
Beside the measured number, compound 3's estimate is 1.1-fold (0.06 log units) above it; low and high end bracket the measured number.
By their numbers in this assay, from the lowest: compounds 2, 3 and 1 (each within the scatter of the next).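

In this assay, the saturated ring carbon now has a reading of its own, since inverting that stereocentre alone gives a 1.7-fold lower number from compound 1 to compound 3 (0.23 log units; within the scatter). Inverting both stereocentres, the full mirror-image change, gives a 1.1-fold higher number from compound 2 to compound 3 (0.03 log units; within the scatter), so this pair of mirror images shows no separation on this read-out. Alongside the chain-carbon step, a 1.8-fold lower number from compound 1 to compound 2 (0.25 log units; within the scatter), neither stereocentre moves the number beyond the scatter, alone or together with the other, and the single-centre comparison at the ring carbon is clean: the fact that compounds 1 and 3 differ only in the configuration as drawn

The mirror image of compound 1, the remaining combination of the two stereocentres, stands outside the compounds shown. Also open, going by these compounds, is whether a hydroxyl group in place of the methoxy group, or a longer chain, would shift the number beyond the scatter.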